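Nitrile in place of fluorine on the fused ring

The source may hold more compounds than are shown below. What is called first, only, known or untested is meant among the compounds shown, and "the series" means these compounds.

Measured compounds:
- compound 1 `Fc1cc(C(F)(F)F)ccc1-c1ccc(Cn2nnc3ccccc32)cc1`: 0.1 mL/min/g
- compound 2 `Fc1cc(Cl)ccc1-c1ccc(Cn2nnc3ccccc32)cn1`: 0.01 mL/min/g
- compound 3 `Fc1cc(Cl)ccc1-c1ccc(Cn2nnc3c(F)cccc32)cn1`: 0.1 mL/min/g

In an ADME assay on microsomes from liver (Homo sapiens) for metabolic stability, tested at 2.5 uM (on this read-out lower numbers stand for slow clearance and higher numbers for fast clearance), compound 3 gives 0.1 mL/min/g, level at the digits shown with compound 1 and together with it the highest of the three numbers; compound 2 sits a full step lower, beyond the scatter. Within the data shown here, the only measured step, a 10-fold higher number from compound 2 to compound 3 (1.00 log units; beyond the scatter), shows that a change at this position of the fused ring can move the number by a clear margin. Compound 4 `N#Cc1cccc2c1nnn2Cc1ccc(-c2ccc(Cl)cc2F)nc1` differs from compound 3 by cyano in place of fluoro on an aromatic carbon. Among the measured compounds shown here, no measured pair shows a cyano entering, so the direction is uncertain; the expectation is a step of a 1.3-fold lower number from compound 3 to compound 4 (0.10 log units; within the scatter) in this assay, within the scatter. Compound 4 is therefore estimated at 0.08 mL/min/g, with a range from 0.02 mL/min/g to 0.3 mL/min/g.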

Compound 4, intrinsic clearance in a liver preparation (reported as CLH), per the amount of preparation that the assay uses: 0.05 mL/min/g
Beside the measured number, compound 4's estimate is 1.6-fold (0.20 log units) above it, and the stated range covers the measured number.
By their numbers in this assay, from the lowest: compound 2; then compounds 4, 1 and 3 (each within the scatter of the next).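

In this assay, swapping fluoro for cyano on this aromatic carbon gives a 2.0-fold lower number from compound 3 to compound 4 (0.30 log units; within the scatter), so the two groups cannot be told apart here. Cyano, like fluoro, still differs clearly from hydrogen at this carbon, with a 5.0-fold higher number from compound 2 to compound 4 (0.70 log units; beyond the scatter). No measurement available here explains this result. Still open, on these data alone, is whether an amine or a carboxylic acid on this aromatic carbon would give a number closer to that of hydrogen or to those of fluoro and cyano. As far as these compounds go, whether cyano would have the same effect on the core of compound 1 is also open.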